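Isobutyl-Bearing Arylidene Analogues and Liver-Cell Cytotoxicity

The source may hold more compounds than are shown below. What is called first, only, known or untested is meant among the compounds shown, and "the series" means these compounds.

Measured compounds:
compound 1, `COc1ccc(/C=C2\S/C(=N\c3ccccc3)N(CC(C)C)C2=O)cc1OC`: > 100000 nM
compound 2, `COc1ccc(/C=C2\S/C(=N\c3ccccc3)N(CC(C)C)C2=O)cc1`: "not determined" (no result reported)

The study reads liver-cell cytotoxicity in an ADME assay on HepG2 cells (Homo sapiens) for cytotoxicity, read by MTT assay, with a stated time of 48 h; on this read-out higher numbers stand for weaker inhibition and lower numbers for stronger inhibition. Compound 1 gives > 100000 nM in this assay, which is a limit of the assay and not a number. Compound 2 carries only the entry "not determined" (no result reported) in this assay, so no single number places it. Among the measured compounds shown here, the one further value shown is the limit of > 100000 nM in this assay, at which 1 of the 2 values shown sits, and nothing in the data sets compound 2 apart from that limit.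

The piece follows the change from compound 2 to compound 3, whose structure is `Cc1ccsc1/C=C1\S/C(=N\c2ccccc2)N(CC(C)C)C1=O`. The difference is 3-methylthiophen-2-yl in place of 4-methoxyphenyl on a double-bonded chain carbon bound to a double-bonded ring carbon. For the measured compounds named here, since no pair of measured compounds differing in one place is available, no measured step can be quoted for this kind of change. Going by the values given here, with the only reported value in this assay being a limit, the expected step is none beyond the scatter, in either direction.

Compound 3 is therefore estimated to give about 100000 nM in this assay, with a range from 30000 nM to 300000 nM, and it is expected that the assay may again report only a limit.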

Compound 3, half-maximal inhibitory concentration: 89200 nM
Compound 3: middle estimate off by 1.1-fold (0.05 log units), on the high side; the range from low to high includes it.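

No step can be read from compound 2 to compound 3: compound 2 has no number in this assay and compound 3 gives 89200 nM there. The compounds shown leave open how the exchange of 4-methoxyphenyl for 3-methylthiophen-2-yl on the shared core, or any other single change, moves this read-out.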